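The source may hold more compounds than are shown below. What is called first, only, known or untested is meant among the compounds shown, and "the series" means these compounds.

Measured compounds:
compound 3 `COc1ccc(CNC(=O)/C(C#N)=C/c2ccc(C)cc2)cc1` – 42000 nM
compound 1 `COc1ccc(CNC(=O)/C(C#N)=C/c2ccc(C)o2)cc1` – 69000 nM
compound 2 `COc1ccc(CNC(=O)/C(C#N)=C/c2cc(Br)co2)cc1` – > 100000 nM (a limit of the assay, not a number)

In a functional assay on SMA cells (Homo sapiens) for inhibition, read by MTT assay, with a stated time of 72 h (on this read-out higher numbers stand for weaker inhibition of growth and lower numbers for stronger inhibition of growth), compound 3 holds the lowest of the two numbers. The nearest is compound 1, and the step of a 1.6-fold lower number from compound 1 to compound 3 (0.22 log units; within the scatter) is within the scatter, so no order can be read between them. Compound 2 reaches only the limit (the limit of > 100000 nM in this assay, at which 1 of the 3 values shown sits). The step of an at least 2.3-fold lower number from compound 2 to compound 3 (0.37 log units; beyond the scatter) is beyond the scatter and is the one separation the set shows.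

Compound 4 `COc1ccc(CNC(=O)/C(C#N)=C/c2ccc(Cl)cc2)cc1` differs from compound 3 by chloro in place of methyl on an aromatic carbon. Within the data shown here, none of the measured steps bears directly on this change: each of them swaps the whole group on the double-bonded chain carbon, and the only step beyond the scatter, an at least 2.3-fold lower number from compound 2 to compound 3 (0.37 log units; beyond the scatter), starts from a limit. The exchange of one substituent on the six-membered ring is a smaller change than any measured. The step of a 1.1-fold higher number from compound 3 to compound 4 (0.03 log units; within the scatter) is therefore expected to stay within the scatter, with no direction. Compound 4 is estimated at 45000 nM, within 18000 nM to 100000 nM.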

Compound 4, concentration for 50% growth inhibition: 17000 nM
Beside the measured number, compound 4's estimate is 2.6-fold (0.42 log units) above it; measured number outside the range, below it.
By their numbers in this assay, from the lowest: compound 4; then compounds 3 and 1 (each within the scatter of the next). At a limit, above all of these: compound 2.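

In this assay, among these compounds, exchanging methyl for chloro on the six-membered aromatic ring gives a step beyond the scatter (a 2.5-fold lower number from compound 3 to compound 4 (0.39 log units; beyond the scatter)) and is the only measured exchange of a single substituent. A change of one heavy atom at this place therefore moves the number, and 4-chlorophenyl also separates from 5-methylfuran-2-yl (a 4.1-fold lower number from compound 1 to compound 4 (0.61 log units; beyond the scatter)), although compounds 1 and 3 could not be ordered. The remaining step (an at least 5.8-fold lower number from compound 2 to compound 4 (0.76 log units; beyond the scatter)) starts from a limit of the assay for compound 2, not from a number: the limit of > 100000 nM in this assay, at which 1 of the 4 values shown sits.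

From the compounds shown here alone, only methyl and chloro appear at this place, so what an amine or a carboxylic acid there would give stays open. Going by these compounds, whether chloro would give a similar step on a furan ring also stays open.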